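Swapping the Pyridinyl Ring for a Terminal Alkyne Chain

This account rests on a few compounds, and the source may have more. Where it says the series, first, only, none or still open, it means among the compounds named here.

Compound 1 `O=c1[nH]/c(=N\OCCOc2ccccc2)ccn1[C@@H]1O[C@H](COP(=O)(O)OP(=O)(O)OP(=O)(O)O)[C@@H](O)[C@H]1O` and compound 2 `O=c1[nH]/c(=N\OCCCc2cccnc2)ccn1[C@@H]1O[C@H](COP(=O)(O)OP(=O)(O)OP(=O)(O)O)[C@@H](O)[C@H]1O` share the same core and differ only in the group at the far end of the side chain. In a functional assay on 1321-N1 cells for agonist activity at P2Y purinoceptor 2 (Homo sapiens), read by scintillation counting and inositol phosphate accumulation (on this read-out higher numbers stand for an effect only at larger amounts of compound and lower numbers for an effect already at smaller amounts), compound 1 gives 3400 nM, whereas compound 2 gives 327 nM, the lower of the two numbers; this is the step of a 10-fold lower number from compound 1 to compound 2 (1.02 log units; beyond the scatter). Compound 3 `C#CCCCO/N=c1/ccn([C@@H]2O[C@H](COP(=O)(O)OP(=O)(O)OP(=O)(O)O)[C@@H](O)[C@H]2O)c(=O)[nH]1` follows from compound 2 by a further change at the end of that chain: ethynyl in place of pyridin-3-yl on a saturated chain carbon, three bonds along the chain from an oxygen. Within the data shown here, the single measured step does not probe this kind of change, since it exchanged one aromatic ring for another rather than removing the ring in favour of a short unsaturated chain, so it gives no direct guide. Among the measured compounds shown here, both measured compounds carry an aromatic ring at this position, and compound 3 is the first without one. The expectation is that compound 3 gives a higher number than compound 2, with an estimated step of a 3.7-fold higher number from compound 2 to compound 3 (0.56 log units; beyond the scatter). Compound 3 is estimated to give 1200 nM, with a likely range from 300 nM to 5000 nM.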

Compound 3, half-maximal effective concentration: 168 nM
For compound 3 the middle estimate is 7.1-fold (0.85 log units) above the measured one; measured number outside the range, below it.
By their numbers in this assay, from the lowest: compounds 3 and 2 (each within the scatter of the next); then compound 1.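

In this assay, a ring at the far end of the side chain proves not to be required for a number in this range: the ring-free pent-4-yn-1-yl chain stands level with the 3-(pyridin-3-yl)propyl chain, with a 1.9-fold lower number from compound 2 to compound 3 (0.29 log units; within the scatter). This holds even though the change removes a whole six-membered aromatic ring and leaves only an ethynyl group at the chain end, while the gap to the phenoxy-bearing chain remains clear, with a 20-fold lower number from compound 1 to compound 3 (1.31 log units; beyond the scatter). Among these three compounds, then, having a ring does not by itself decide the result, as compound 1 and compound 2 both carry one yet sit far apart, and no available data explain why the ethynyl and pyridin-3-yl ends give such similar results.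

The compounds shown leave open whether the triple bond matters or the chain alone is enough, a question that a plain saturated pentyl chain would address. From the compounds shown here alone, how far this position tolerates other ends also remains open, for example a longer hex-5-yn-1-yl chain or a terminal amine.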